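Dropping the Methylthiophene Arm from Compound 1

A few compounds are considered here, and "the series" means these few. Any claim that something is new, unique, unknown or untested is made for them only; others in the source may bear on it.

Compound 1 `CCOc1cc(NC(=O)CCCCCC(=O)Nc2cc(-c3ccc(C)s3)ccc2N)cc2c1OCC([N+](=O)[O-])=C2` gives 36% in an assay on isolated protein for inhibition of protein deacetylase HDAC6 (Homo sapiens), read by fluorescence, with stated times of 10 min and 30 min, tested at 10 uM (a lower number here means less inhibition, a higher number more inhibition at the concentration tested (going by the name of the read-out)), the highest of the three numbers recorded. Compound 3 `CCOc1cc(NC(=O)CCCCC(=O)Nc2cc(-c3ccccc3)ccc2N)cc2c1OCC([N+](=O)[O-])=C2` gives 25% in this assay, a gap beyond the usual scatter, and compound 2 `CCOc1cc(NC(=O)CCCCCCC(=O)Nc2cc(-c3ccc(C)s3)ccc2N)cc2c1OCC([N+](=O)[O-])=C2` gives 19% in this assay, further down still. Compound 4 `CCOc1cc(NC(=O)CCCCCC(=O)Nc2ccccc2N)cc2c1OCC([N+](=O)[O-])=C2` differs from compound 1 in one place: hydrogen in place of 5-methylthiophen-2-yl on an aromatic carbon. No measured pair changes in just that place, so the size of the step is not shown by the data. Loss of the whole aryl group is expected to cost inhibition, and a downward step is estimated, a number 14 percentage points lower from compound 1 to compound 4 (beyond the scatter). Compound 4 is therefore expected to give about 22% in this assay, within a range from 8% to 38%.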

Compound 4, a percentage reported as inhibition, at one concentration (the size of the read-out at that concentration, not a potency): 57%
Estimate against measurement, compound 4: 35 percentage points below; measured number above the stated range.
By their numbers in this assay, from the lowest: compounds 2 and 3 (each within the scatter of the next); then compound 1; then compound 4.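

In this assay, hydrogen in place of 5-methylthiophen-2-yl on the aromatic carbon para to the amino group gives a number 21 percentage points higher from compound 1 to compound 4 (beyond the scatter). With this chain, then, inhibition at the concentration tested does not depend on having the 5-methylthiophen-2-yl group at this carbon, and the number is higher with the unsubstituted ring. Nothing available accounts for the rise.

From the compounds shown here alone, whether a single methyl group or a fluorine at this carbon would give a similar number remains open. So does whether removing the aryl group from the compounds with a shorter or longer chain would give a step of this size.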